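A trifluoromethyl group on the benzyl of compound 1

A few compounds are considered here, and "the series" means these few. Any claim that something is new, unique, unknown or untested is made for them only; others in the source may bear on it.

Measured in a functional assay on PC-9 cells (Homo sapiens) for inhibition, read by MTT assay, with a stated time of 72 h; on this read-out higher numbers stand for weaker inhibition and lower numbers for stronger inhibition:
- compound 1 `Cc1cc(Nc2ccn(Cc3ccccc3)n2)n2nc(SCc3ccc(Br)cc3)nc2n1`: > 50000 nM
- compound 2 `CCCSc1nc2nc(C)cc(Nc3cc(-c4ccccc4)[nH]n3)n2n1`: > 50000 nM
- compound 3 `Cc1cc(Nc2cc(-c3ccccc3)[nH]n2)n2ncnc2n1`: > 50000 nM

Each of these entries is a limit and not a number, as the limit of > 50000 nM in this assay, at which 3 of the 3 values shown sit, shows. Compound 1 therefore stands at a limit, > 50000 nM. Compound 4 `Cc1cc(Nc2ccn(Cc3ccc(C(F)(F)F)cc3)n2)n2nc(SCc3ccc(Br)cc3)nc2n1` differs from it by trifluoromethyl in place of hydrogen on an aromatic carbon, with trifluoromethyl in place of hydrogen on an aromatic carbon, so that benzyl becomes 4-(trifluoromethyl)benzyl. Among the measured compounds shown here, the only measured step, a step that the two limits leave unreadable from compound 2 to compound 3, lies elsewhere on the molecule and gives no size to carry over. In this assay, no change beyond the scatter is therefore expected, in either direction. The expected outcome is an at least 1.1-fold lower number from compound 1 to compound 4 (0.04 log units; that floor lies within the scatter). Compound 4 is estimated at 45000 nM, with an expected range of 15000 nM to 60000 nM.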

Compound 4, half-maximal inhibitory concentration: 5580 nM
Compound 4: middle estimate off by 8.1-fold (0.91 log units), on the high side, outside the stated range (below it).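

In this assay, trifluoromethyl on the benzyl, para to a large group, gives the only readable step among these compounds: an at least 8.9-fold lower number from compound 1 to compound 4 (0.95 log units; beyond the scatter). Among the compounds shown here, this shows that the benzyl of compound 1 is a place where a single change can move the read-out, which the earlier compounds, all sitting at a limit, could not show. The size of this step is a floor and not a full measure, since compound 1 stands at a limit: the limit of > 50000 nM in this assay, at which 3 of the 4 values shown sit.

The compounds shown leave open whether a chlorine, a methoxy group or an amine at this place would give a similar step. They also leave open whether trifluoromethyl elsewhere on the benzyl would do the same.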